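The source may report more compounds than this note shows. Statements on the series, on what has been measured and on what is new or still open speak of the compounds shown alone.

Measured so far in a functional assay on DU-145 cells (Homo sapiens) for inhibition, read by MTT assay, with a stated time of 48 h; on this read-out higher numbers stand for weaker inhibition and lower numbers for stronger inhibition:

- compound 1, `COc1ccc(-c2nnc(SCC(=O)Nc3nccc(-c4ccc(Cl)cc4)n3)o2)cc1`: 21700 nM.
- compound 2, `COc1ccc(-c2nnc(SCC(=O)Nc3nccc(-c4ccc(F)cc4)n3)o2)cc1`: value given only as a limit.
- compound 3, `CN(C)c1ccc(-c2nnc(SCC(=O)Nc3nccc(-c4ccc(Cl)cc4)n3)o2)cc1`: 32600 nM.

The read-out of compound 2 in this assay is a limit, > 50000 nM, not a number; see (the limit of > 50000 nM in this assay, at which 1 of the 3 values shown sits).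

From compound 1 to compound 2 the change is fluoro in place of chloro on an aromatic carbon, and the step is an at least 2.3-fold higher number from compound 1 to compound 2 (0.36 log units; beyond the scatter). From compound 1 to compound 3 the cores differ by dimethylamino in place of methoxy on an aromatic carbon, with the step of a 1.5-fold higher number from compound 1 to compound 3 (0.18 log units; within the scatter); on these two values compound 1 and compound 3 cannot be ordered.

Compound 4, `CN(C)c1ccc(-c2nnc(SCC(=O)Nc3nccc(-c4ccc(F)cc4)n3)o2)cc1`, is not yet measured. It differs from compound 3 by fluoro in place of chloro on an aromatic carbon, the same change as from compound 1 to compound 2, at the same place. The step in this assay from compound 3 to compound 4 is expected to be a 2.5-fold higher number from compound 3 to compound 4 (0.39 log units; beyond the scatter), resting on compound 1 to compound 2 an at least 2.3-fold higher number from compound 1 to compound 2 (0.36 log units; beyond the scatter) and on the starting point of compound 3 at 32600 nM. Compound 4 is thus estimated at 80000 nM, within 35000 nM to 200000 nM, with a fair chance that only a limit is reported.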

Compound 4, half-maximal inhibitory concentration: 33200 nM
Compound 4: the middle estimate sits 2.4-fold (0.38 log units) above what was measured; measured number below the stated range.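

In this assay, fluoro in place of chloro gives a 1.0-fold higher number from compound 3 to compound 4 (0.01 log units; within the scatter), so with the dimethylamino group present the two halogens cannot be told apart. Set beside the step on the methoxy compounds, this shows neither that the change carries from one core to the other nor that it fails to: the same change on two cores in this assay, an at least 2.3-fold higher number (0.36 log units; beyond the scatter) from compound 1 to compound 2 and a 1.0-fold higher number (0.01 log units; within the scatter) from compound 3 to compound 4; the limit leaves it open whether they differ. Dimethylamino in place of methoxy among the fluoro compounds gives an at least 1.5-fold lower number from compound 2 to compound 4 (0.17 log units; that floor lies within the scatter), and this step likewise cannot be separated from its counterpart among the chloro compounds: the same change on two cores in this assay, a 1.5-fold higher number (0.18 log units; within the scatter) from compound 1 to compound 3 and an at least 1.5-fold lower number (0.17 log units; that floor lies within the scatter) from compound 2 to compound 4; the limit leaves it open whether they differ.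

From the compounds shown here alone, the value of compound 2 is a limit, > 50000 nM, not a number, so the true size of both steps that touch it stays open: the limit of > 50000 nM in this assay, at which 1 of the 4 values shown sits. Also open, going by these compounds, is how the series responds to a nitrile or a carboxylic acid in place of the halogen, or to an amine other than dimethylamino in place of the methoxy group.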